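The source may hold more compounds than are shown below. What is called first, only, known or untested is meant among the compounds shown, and "the series" means these compounds.

Measured so far in this series:
compound 1 `O=C1c2ccccc2N(Cc2ccc(Cl)cc2)S(=O)(=O)N1Cc1ccccc1` — 19700 nM
compound 2 `O=C1c2ccccc2N(Cc2ccccc2Cl)S(=O)(=O)N1Cc1ccccc1` — 27900 nM
compound 3 `O=C(OCOCN1c2ccccc2C(=O)N(Cc2ccccc2)S1(=O)=O)c1ccccc1` — 100000 nM

In a functional assay on CCRF-CEM cells (Homo sapiens) for inhibition (on this read-out higher numbers stand for lower toxicity in this test and lower numbers for higher toxicity in this test), compound 3 gives 100000 nM, the highest of the three numbers; compound 2 at 27900 nM is nearest and compound 1 at 19700 nM furthest, both gaps beyond the scatter.

Compound 4 `C#CCOCN1c2ccccc2C(=O)N(Cc2ccccc2)S1(=O)=O` differs from compound 3 by ethynyl in place of benzoyloxy on a saturated chain carbon bound to an oxygen on a saturated carbon. Going by the values given here, the only measured step, a 1.4-fold higher number from compound 1 to compound 2 (0.15 log units; within the scatter), concerns the group on a saturated chain carbon bound to a sulfonamide nitrogen in a ring, a different place, and was within the scatter. Among the compounds with values here, no measured pair covers the position changed here, so the expectation rests on compound 3 alone. Compound 4 is expected to give 55000 nM, with a range of 18000 nM to 150000 nM. The estimated step of a 1.8-fold lower number from compound 3 to compound 4 (0.26 log units; within the scatter) is a modest lowering that may well stay within the scatter.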

Compound 4, half-maximal cytotoxic concentration: 23000 nM
Beside the measured number, compound 4's estimate is 2.4-fold (0.38 log units) above it, and the stated range covers the measured number.
By their numbers in this assay, from the lowest: compounds 1, 4 and 2 (each within the scatter of the next); then compound 3.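

In this assay, going by these compounds alone, ethynyl in place of benzoyloxy gives a 4.3-fold lower number from compound 3 to compound 4 (0.64 log units; beyond the scatter) and lies beyond the scatter, the first change at this place with a measured effect. The steps of a 1.2-fold lower number from compound 2 to compound 4 (0.08 log units; within the scatter) and a 1.2-fold higher number from compound 1 to compound 4 (0.07 log units; within the scatter) are both within the scatter, so this read-out does not separate those compounds. No measured evidence bears on the cause of these results. Going by these compounds, whether an amine or a carboxylic acid in place of ethynyl would stay level with compound 4 or move towards compound 3 remains open, as does the effect of a longer chain.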